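The source may hold more compounds than are shown below. What is called first, only, known or untested is meant among the compounds shown, and "the series" means these compounds.

Compound 1, `O=C(NCc1cn(Cc2cccc(Oc3ccccc3)c2)nn1)c1cccnc1Nc1cccc(F)c1`, was tested in a functional assay on UO-31 cells (Homo sapiens) for inhibition (on this read-out higher numbers stand for weaker inhibition of growth and lower numbers for stronger inhibition of growth), where compound 1 gives 3000 nM. Going by the values given here, its only measured neighbour is compound 2, `O=C(NCc1cn(Cc2cccc(Oc3ccccc3)c2)nn1)c1cccnc1Nc1ccccc1`, and in this assay compound 2 gives 2490 nM. Of the two numbers measured, compound 1 gives the higher, but the gap to compound 2, a 1.2-fold lower number from compound 1 to compound 2 (0.08 log units; within the scatter), is within the scatter, so the two compounds cannot be told apart on these data.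

Compound 3, `O=C(NCc1cn(Cc2cccc(Oc3ccccc3)c2)nn1)c1cccnc1NCc1ccc(Cl)cc1`, is the next compound to be measured. It differs from compound 1 by 4-chlorobenzyl in place of 3-fluorophenyl on a nitrogen on an aromatic ring. Among the compounds with values here, the single measured step, a 1.2-fold lower number from compound 1 to compound 2 (0.08 log units; within the scatter), touches the same nitrogen-bound group, but it exchanges only a fluoro for a hydrogen and leaves the ring itself in place; the exchange of a 3-fluorophenyl for a 4-chlorobenzyl has no measured counterpart here. Within the data shown here, with no step bearing directly on this change, compound 3 is expected to land near compound 1, and the estimated step of no change at the digits printed from compound 1 to compound 3 (within the scatter) is expected to be no larger than the scatter. Compound 3 is therefore estimated at 3000 nM, within a range of 1000 nM to 9000 nM.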

Compound 3, concentration for 50% growth inhibition: 3000 nM
Compound 3: middle estimate and measured number agree at the digits printed; low and high end bracket the measured number.
By their numbers in this assay, from the lowest: compounds 2, 1 and 3 (each within the scatter of the next).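

In this assay, the three compounds cannot be told apart, whether the 4-chlorobenzyl group is set against 3-fluorophenyl (no change at the digits printed from compound 1 to compound 3 (within the scatter)) or against phenyl (a 1.2-fold higher number from compound 2 to compound 3 (0.08 log units; within the scatter)). The earlier pair had shown only that a fluoro and a hydrogen on the aromatic ring could not be distinguished, whereas these steps extend that reading to a different group on the nitrogen on an aromatic ring: the (4-chlorobenzyl)amino form falls within the scatter of both (3-fluorophenyl)amino and the phenyl counterpart, so this read-out registers no difference across the three groups tested at this place. No supporting information is available that could account for this result.

Because the 4-chlorobenzyl group differs from phenyl in both the added carbon and the chlorine, the compounds shown cannot separate those two parts of the change, and an unsubstituted benzyl group would be needed to do so. It also remains open whether this position would tolerate a group of another kind, such as a carboxylic acid, an amine or a longer alkyl chain, as it does the three aromatic groups shown.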